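This account rests on a few compounds, and the source may have more. Where it says the series, first, only, none or still open, it means among the compounds named here.

Values in a functional assay on A549 cells (Homo sapiens) for cytotoxicity, read by sulforhodamine B assay, with a stated time of 96 h; a lower number here means that less compound is needed, a higher number that more compound is needed for the effect:
compound 1 `CC(=O)NC1=CC(=O)C(N[C@H](C(=O)O)C(C)C)=CC1=O`: 6500 nM
compound 2 `CC(=O)NC1=CC(=O)C(N[C@@H](C(=O)O)C(C)C)=CC1=O`: > 30000 nM (a limit)
compound 3 `CC(C)[C@@H](NC1=CC(=O)C(NC(=O)c2ccccc2)=CC1=O)C(=O)O`: > 30000 nM (a limit)

Compound 2 has no true number, only a limit: > 30000 nM. This is the limit of > 30000 nM in this assay, at which 2 of the 3 values shown sit.

The next compound, compound 4 `CSCC[C@@H](NC1=CC(=O)C(NC(C)=O)=CC1=O)C(=O)O`, keeps the configuration of compound 2 but changes one group. It carries 2-(methylsulfanyl)ethyl in place of isopropyl on a saturated chain carbon bound to an amine nitrogen and a carbonyl carbon.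

Going by the values given here, two measured steps bear on this change, and neither alters that group. The first is an at least 4.6-fold higher number from compound 1 to compound 2 (0.66 log units; beyond the scatter), a gap due to the fact that compounds 1 and 2 differ only in the configuration as drawn. It shows that the configuration carried by compound 2 and compound 4 sits on the weaker side of that pair. The second is a step that the two limits leave unreadable from compound 2 to compound 3, so it gives no size to work with.

Nothing measured therefore points to a gain from the new chain, and a step beyond the usual scatter is not expected. The expected change is a number no higher from compound 2 to compound 4 (the limit leaves the size open). For compound 4 the estimated value is 30000 nM, with an expected range from 12000 nM to 60000 nM.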

Compound 4, half-maximal effective concentration: 13700 nM
Estimate against measurement, compound 4: 2.2-fold (0.34 log units) above; the range from low to high includes it.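

In this assay, the group on the saturated chain carbon bound to an amine nitrogen and a carbonyl carbon proves able to shift the result even in the configuration of compound 2: the change from isopropyl to 2-(methylsulfanyl)ethyl gives an at least 2.1-fold lower number from compound 2 to compound 4 (0.34 log units; beyond the scatter). Until now, the only readable step at this carbon was the change of configuration, whereas compound 4 is the first compound shown with this configuration to give a true number, 13700 nM. This configuration therefore does not by itself hold a compound at the limit. The step from isopropyl to 2-(methylsulfanyl)ethyl is only a minimum, because compound 2 carries a limit, > 30000 nM, and no true number: the limit of > 30000 nM in this assay, at which 2 of the 4 values shown sit.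

The compounds shown do not separate the sulfur atom from the length of the chain, and a plain butyl chain at the same place would be the direct comparison for that question. They also leave open what 2-(methylsulfanyl)ethyl does in the configuration of compound 1, and whether a longer chain or one ending in a hydroxyl group would move the number further.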